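This account rests on a few compounds, and the source may have more. Where it says the series, first, only, none or still open, it means among the compounds named here.

Working notes on the series:

- compound 1 `COc1ccccc1CNc1nc(Nc2ccc(N3CCN(C)CC3)cn2)ncc1Cl`: 29300 nM
- compound 2 `CN1CCN(c2ccc(Nc3ncc(Cl)c(NCc4ccco4)n3)nc2)CC1`: 11000 nM

In a functional assay on MDA-MB-231 cells (Homo sapiens) for inhibition, read by CCK-8 assay, with a stated time of 48 h (a higher number here means a weaker inhibitor of growth, a lower number a stronger inhibitor of growth), compound 2 holds the lower of the two numbers at 11000 nM. Compound 3 `Cc1ccc(Nc2nc(Nc3ccc(N4CCN(C)CC4)cn3)ncc2Cl)cc1` differs from compound 2 by 4-methylphenyl in place of (furan-2-yl)methyl on a nitrogen on an aromatic ring, with 4-methylphenyl in place of (furan-2-yl)methyl on a nitrogen on an aromatic ring. For the measured compounds named here, the one measured step that bears on this is modest: a 2.7-fold lower number from compound 1 to compound 2 (0.43 log units; beyond the scatter). That change kept the saturated chain carbon that compound 3 lacks, so it is a loose guide and sets no direction. No shift beyond the scatter is expected in this assay, the expected change being a 1.1-fold lower number from compound 2 to compound 3 (0.04 log units; within the scatter). For compound 3 the estimated value is 10000 nM, with an expected range of 3000 nM to 30000 nM.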

Compound 3, concentration for 50% growth inhibition: 4030 nM
Compound 3: middle estimate off by 2.5-fold (0.39 log units), on the high side; the range from low to high includes it.
By their numbers in this assay, from the lowest: compound 3; then compound 2; then compound 1.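

At this nitrogen on an aromatic ring, 4-methylphenyl gives the lowest number of the three compounds in this assay, ahead of (furan-2-yl)methyl (a 2.7-fold lower number from compound 2 to compound 3 (0.44 log units; beyond the scatter)) and 2-methoxybenzyl (a 7.3-fold lower number from compound 1 to compound 3 (0.86 log units; beyond the scatter)). Both steps lie beyond the scatter, so a saturated chain carbon on this nitrogen is not needed for growth inhibition in this series. No measurement shown gives a reason for these steps.

The step from compound 2 to compound 3 swaps the ring and removes the chain carbon together, so their contributions remain unseparated. Also open, going by these compounds, is how a carboxylic acid or an amine in place of the methyl of 4-methylphenyl would read.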